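The compounds below may be only part of what the source reports. "The series", "measured", "known", "first", "only" and "open" are said of these compounds alone.

Of the compounds shown here, two sharing one core have been measured in a physicochemical assay, read by spectrophotometry, with a stated time of 15 min; a higher number here means a weaker inhibitor, a lower number a stronger inhibitor. Compound 1 `COc1cc(/C=N/NC(=O)CCCc2nc3ccccc3c(=O)[nH]2)cc(O)c1O` gives 80000000 nM in this assay. Among the compounds with values here, compound 2 `COc1ccc(/C=N/NC(=O)CCCc2nc3ccccc3c(=O)[nH]2)cc1` gives 280000000 nM in this assay, the highest of the two numbers; its only neighbour, compound 1, sits lower by a gap that lies beyond the scatter of repeated measurements. Compound 3 `O=C(CCCc1nc2ccccc2c(=O)[nH]1)N/N=C/c1ccc(O)c(O)c1` has not yet been measured in this assay. Compared with compound 2, it carries 3,4-dihydroxyphenyl in place of 4-methoxyphenyl on a carbon with a double bond to nitrogen. Within the data shown here, with only two measured points and no single-change pair among them, the step can only be guessed from where compound 1 stands: compound 1, which also carries hydroxyl groups on this ring, gives the lower number. The change from compound 2 to compound 3 is therefore expected to lower the number, by about a 4.0-fold lower number from compound 2 to compound 3 (0.60 log units; beyond the scatter). Compound 3 is accordingly estimated at 70000000 nM in this assay, within a range of 20000000 nM to 250000000 nM.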

Compound 3, half-maximal inhibitory concentration: 75000000 nM
Compound 3: middle estimate off by 1.1-fold (0.03 log units), on the low side; low and high end bracket the measured number.
By their numbers in this assay, from the lowest: compounds 3 and 1 (each within the scatter of the next); then compound 2.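

In this assay, within the data shown here, the first single-change comparison at this position shows that putting 3,4-dihydroxyphenyl in place of 4-methoxyphenyl on the carbon with a double bond to nitrogen gives a 3.7-fold lower number from compound 2 to compound 3 (0.57 log units; beyond the scatter), a step beyond the scatter of repeated measurements. A second single change, hydrogen in place of methoxy on an aromatic carbon, gives a 1.1-fold lower number from compound 1 to compound 3 (0.03 log units; within the scatter), which lies within that scatter, so this methoxy group makes no readable difference when the two hydroxyl groups are on the ring. No separate measurement is available to explain either result.

The compounds shown do not reveal whether both hydroxyl groups are needed or whether a single hydroxyl group would give the same step. From the compounds shown here alone, what an amine or a carboxylic acid on this ring would do also remains open.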